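Isopropyl to trifluoromethyl on the aromatic oxygen

This account rests on a few compounds, and the source may have more. Where it says the series, first, only, none or still open, it means among the compounds named here.

Measured so far:
- compound 1 `COc1cc(-n2ncnc2-c2cccc([N+](=O)[O-])c2)cc(OC)c1OC`: > 10000 nM
- compound 2 `COc1cc(-n2ncnc2-c2ccc(OC(C)C)cc2)cc(OC)c1OC`: 610 nM

In a functional assay on MCF7 cells (Homo sapiens) for antiproliferative activity, read by MTT assay, with a stated time of 72 h (on this read-out lower numbers stand for stronger inhibition and higher numbers for weaker inhibition), compound 1 returns > 10000 nM, which is a limit of the assay and not a number. In this assay, among the compounds with values here, compound 2 returns 610 nM, the only number in the set. Within the data shown here, compound 2 is therefore the sole anchor for a numerical comparison, and there is no measured step from which to read the size of any change yet.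

Compound 3 `COc1cc(-n2ncnc2-c2ccc(OC(F)(F)F)cc2)cc(OC)c1OC` is the next member. It differs from compound 2 by trifluoromethyl in place of isopropyl on an oxygen on an aromatic ring. The oxygen stays in place and the substituent on it is exchanged, so the change is confined to the group beyond the oxygen.

Among the measured compounds shown here, with no measured pair available, the expectation for the step from compound 2 to compound 3 is that it stays small, within or at the edge of the usual scatter, and if anything slightly toward weaker inhibition, as a 1.5-fold higher number from compound 2 to compound 3 (0.17 log units; within the scatter). Compound 3 is accordingly estimated at 900 nM in this assay, expected to fall between 300 nM and 3000 nM.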

Compound 3, half-maximal inhibitory concentration: > 10000 nM
Compound 3 ended at the assay's limit; the forecaster's own chance of this, stated with the estimate: 10%; middle value at least 11-fold (1.04 log units) away from the limit.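

The group beyond the oxygen matters in this series: with the oxygen unchanged, isopropoxy to trifluoromethoxy gives an at least 16-fold higher number from compound 2 to compound 3 (1.21 log units; beyond the scatter) in this assay, the first measured step available here. Compound 3 gives > 10000 nM, which is a limit of the assay and not a number. The step therefore fixes only a minimum size, and activity at this place depends on what the oxygen carries, not on the oxygen alone: the limit of > 10000 nM in this assay, at which 2 of the 3 values shown sit.

The compounds shown cannot separate the loss of isopropyl from the arrival of trifluoromethyl, so it remains open whether the activity of compound 2 requires isopropyl itself or would survive with a methyl, an ethyl or a longer chain on the oxygen. Also open, from the compounds shown here alone, is whether a partly fluorinated chain such as difluoromethyl on the oxygen would fall nearer compound 2 or compound 3, and whether an amine or a carboxylic acid in place of the whole isopropoxy group would keep any measurable inhibition.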